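The compounds below may be only part of what the source reports. "The series", "measured", "known", "first", "only" and "open" are said of these compounds alone.

Working notes on the series, plasma exposure in mouse.

Compound 1 `C[C@H](C(=O)O)n1nc(Cn2cc3cc(OCC4CC4)c(Cl)cc3n2)c2ccccc2c1=O` gives 4750000 nM in an ADME assay on the whole organism (Mus musculus, strain CD1) for pharmacokinetics, read by LC-MS, with a stated time of 24 h, at a dose of 5 mg/kg by the oral route; a lower number here means less compound in the circulation, a higher number more compound in the circulation at the dose given. Compound 3 `C[C@H](C(=O)O)c1nn(Cc2cn3cc(OCC4CC4)c(Cl)cc3n2)c2ccccc2c1=O` gives 2610000 nM in this assay, and compound 2 `O=C(O)Cn1nc(Cc2cn3cc(OCC4CC4)c(Cl)cc3n2)c2ccccc2c1=O` gives 1040000 nM. Compound 1 holds the highest number of the three: the gap to compound 3 is within the scatter, so the two are not told apart, while the gap to compound 2 is beyond it. Compound 2 and compound 3 differ in more than one place, so the lower number of compound 2 cannot be tied to any single change.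

Compound 4 `O=C(O)Cn1nc(Cn2cc3cc(OCC4CC4)c(Cl)cc3n2)c2ccccc2c1=O` has not been measured in this assay. Against compound 1 the change is hydrogen in place of methyl on a saturated chain carbon bound to an aromatic nitrogen and a carbonyl carbon. Going by the values given here, no step between measured compounds isolates this change. Only the lower reading of compound 2, which also carries the carboxymethyl group, points toward a decrease, and that on another core. The step from compound 1 to compound 4 is therefore expected to be modest and downward, at a 1.9-fold lower number from compound 1 to compound 4 (0.28 log units; within the scatter), with little confidence in its size. In this assay compound 4 is estimated at 2500000 nM, within a range of 1000000 nM to 5500000 nM.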

Compound 4, maximal plasma concentration: 3140000 nM
Compound 4: middle estimate off by 1.3-fold (0.10 log units), on the low side, and the stated range covers the measured number.
By their numbers in this assay, from the lowest: compound 2; then compounds 3, 4 and 1 (each within the scatter of the next).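

Hydrogen in place of methyl on a saturated chain carbon bound to an aromatic nitrogen and a carbonyl carbon (1-carboxyethyl to carboxymethyl) now has a direct reading in this assay (a 1.5-fold lower number from compound 1 to compound 4 (0.18 log units; within the scatter)), and this step lies within the scatter. On the core of compound 1, the methyl at this position is therefore not shown to change the maximal plasma concentration, and compound 1 and compound 4 are not told apart. No measured evidence bears on this result.

As far as these compounds go, whether the same change reads alike on the core of compound 2 stays open, as does the opposite configuration at this carbon. Also open, from the compounds shown here alone, is how an ethyl group at this carbon, or an amide in place of the carboxylic acid, would read in this assay on the core of compound 1.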